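This account rests on a few compounds, and the source may have more. Where it says the series, first, only, none or still open, it means among the compounds named here.

The compounds measured so far in a physicochemical assay for lipophilicity, read by LC-MS, in phosphate buffer, measured as octanol-water partition, with a stated time of 1 h, at pH 7.4; a higher number here means a more lipophilic compound, a lower number a more polar compound:

Compound 1, `CCC(Nc1ccc(S(=O)(=O)Nc2nccs2)cc1Cl)c1ccccc1`, gives 3.7.
Compound 2, `CC(Nc1ccc(S(=O)(=O)Nc2nccs2)cc1Cl)c1ccccc1`, gives 3.2.
Compound 3, `C[C@H](Nc1cc(F)c(S(=O)(=O)Nc2cscn2)cc1Cl)c1cc(F)ccc1F`, gives 3.5.

Compound 1 and compound 2 share one core and differ in a single spot. The change is hydrogen in place of methyl on a saturated chain carbon, two bonds along the chain from an aromatic carbon and a nitrogen on an aromatic ring. In this assay this reads as a number 0.50 log units lower from compound 1 to compound 2 (beyond the scatter), a step that lies beyond the usual scatter of the measurement.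

Compound 3 sits on a different core. The difference between the core of compound 3 and the core of compound 1 is not broken down here. In this assay compound 3 gives 3.5; this value and the value of compound 1 lie within the scatter of each other, as do this value and the value of compound 2, so no order between them can be claimed.

Compound 4, `O=S(=O)(Nc1cscn1)c1cc(Cl)c(NCc2cc(F)ccc2F)cc1F`, has not yet been measured in this assay. It differs from compound 3 by hydrogen in place of methyl on a saturated chain carbon bound to an aromatic carbon and a nitrogen on an aromatic ring. For the measured compounds named here, this is the same kind of change as the one from compound 1 to compound 2, but not the same: there the carbon that loses the methyl sits two bonds along the chain from an aromatic carbon and a nitrogen on an aromatic ring, here it is bound directly to both. Because a number 0.50 log units lower from compound 1 to compound 2 (beyond the scatter) was seen on the first core, a step of similar size is expected on the second, a number 0.50 log units lower from compound 3 to compound 4 (beyond the scatter). For compound 4 the expected value in this assay is 3, with a likely range from 2.5 to 3.5.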

Compound 4, distribution coefficient: 3.2
Estimate against measurement, compound 4: 0.20 log units below, and the stated range covers the measured number.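

In this assay, putting hydrogen in place of methyl gives a step beyond the usual scatter on the core of compound 1 (a number 0.50 log units lower from compound 1 to compound 2 (beyond the scatter)). The same kind of change, with the carbon now bound directly to an aromatic carbon and a nitrogen on an aromatic ring, gives a step that stays within the scatter on the second core (a number 0.30 log units lower from compound 3 to compound 4 (within the scatter)), so this pair neither confirms that the earlier step carries over nor shows that it is absent, and with a single pair on each core, nothing here shows that the two cores respond differently. Nothing among the data shown accounts for how either step reads.

The compounds shown leave open whether repeating this change on further cores would give steps that stand clear of the scatter, since two pairs are too few to set a trend. They also leave open how this assay would read with a larger or quite different group on that saturated chain carbon, such as a propyl chain, an amine or a carboxylic acid, in place of the methyl.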